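Sec-Butyl to Isobutyl at the Amino Acid Side Chain

The source may report more compounds than this note shows. Statements on the series, on what has been measured and on what is new or still open speak of the compounds shown alone.

Of the compounds shown here, three sharing one core have been measured in a functional assay on the whole organism (Tail, strain ICR) with Mus musculus as the target, in the tail flick test, with a stated time of 30 min, at a dose of 25 umol/kg by the oral route; on this read-out higher numbers stand for a stronger effect at the one dose given and lower numbers for a weaker effect. Compound 1, `CSCC[C@H](NC(=O)CN(c1nc(Cl)nc2[nH]cnc12)C1CC1)C(=O)OCc1ccccc1`, gives 22.2%, and compound 2, `N=C(N)NCCC[C@H](NC(=O)CN(c1nc(Cl)nc2[nH]cnc12)C1CC1)C(=O)OCc1ccccc1`, gives 23.2%; the step of a number 1 percentage points higher from compound 1 to compound 2 (within the scatter) separates them. Compound 3, `CC[C@H](C)[C@H](NC(=O)CN(c1nc(Cl)nc2[nH]cnc12)C1CC1)C(=O)OCc1ccccc1`, gives 41.4% and stands highest of the three numbers, with compound 2 nearest and compound 1 furthest, both beyond the scatter. The steps of a number 19.2 percentage points higher from compound 1 to compound 3 (beyond the scatter) and a number 18.2 percentage points higher from compound 2 to compound 3 (beyond the scatter) both end at the sec-butyl group of compound 3.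

Compound 4, `CC(C)C[C@H](NC(=O)CN(c1nc(Cl)nc2[nH]cnc12)C1CC1)C(=O)OCc1ccccc1`, differs from compound 3 by isobutyl in place of sec-butyl on a saturated chain carbon bound to an amide-type nitrogen and a carbonyl carbon. The measured steps bear on this change only loosely: each exchanges a side chain carrying sulfur or nitrogen for sec-butyl, whereas here one four-carbon group replaces another at the same place. Among the compounds with values here, no measured pair compares two such alkyl groups, so the data give no direction for the step. Compound 4 is therefore expected to stay close to compound 3, with a step of a number 3.4 percentage points lower from compound 3 to compound 4 (within the scatter) that falls within the scatter. The estimate for compound 4 in this assay is 38%, expected to lie between 20% and 56%.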

Compound 4, a percentage reported as activity, at one dose (the size of the read-out at that dose, not a potency): 33.9%
Beside the measured number, compound 4's estimate is 4.1 percentage points above it; the range from low to high includes it.
By their numbers in this assay, from the lowest: compounds 1 and 2 (each within the scatter of the next); then compounds 4 and 3 (each within the scatter of the next).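

In this assay, within the data shown here, the exchange of isobutyl for sec-butyl on a saturated chain carbon bound to an amide-type nitrogen and a carbonyl carbon gives the first comparison of two four-carbon alkyl groups at this place, and the step of a number 7.5 percentage points lower from compound 3 to compound 4 (within the scatter) means that the two cannot be told apart, even though the same atoms are joined differently and the defined stereocentre of sec-butyl leaves with the group. The advantage over the side chains carrying sulfur or nitrogen is therefore not confined to sec-butyl, since compound 4 also stands clear of both, with a number 11.7 percentage points higher from compound 1 to compound 4 (beyond the scatter) and a number 10.7 percentage points higher from compound 2 to compound 4 (beyond the scatter), though these steps are modest. No measurement is available that would explain this shared advantage of the two four-carbon groups.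

The compounds shown leave open how a smaller alkyl group such as isopropyl, a longer chain such as n-hexyl, a benzyl group, or a side chain ending in a carboxylic acid or an amine would read at this place. They also leave open whether the similarity of sec-butyl and isobutyl would hold at other doses or times, as each compound is reported at a single dose and time.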